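The source may hold more compounds than are shown below. What is called first, only, known or untested is meant among the compounds shown, and "the series" means these compounds.

Measured so far:
compound 1, `Cc1cc(-c2cc(-c3cc(O)c(O)c([N+](=O)[O-])c3)on2)on1`: 32.4%
compound 2, `O=[N+]([O-])c1cc(-c2cc(-c3ccncc3)no2)cc(O)c1O`: 32.1%

Both were run in a functional assay on the whole organism (liver, strain NMRI) for inhibition, with Mus musculus as the target, with a stated time of 3 h, at a dose of 3 mg/kg by the oral route; on this read-out higher numbers stand for more inhibition at the one dose given (going by the name of the read-out) and lower numbers for less inhibition. Among the measured compounds shown here, compound 2 stands lowest of the two numbers, but its only neighbour is compound 1, and the gap between them is within the scatter, so the two values do not separate. The unmeasured compound 3, `O=[N+]([O-])c1cc(-c2cc(-c3ccccn3)no2)cc(O)c1O`, differs from compound 2 at one place: pyridin-2-yl in place of pyridin-4-yl on an aromatic carbon. The two have the same atoms, joined differently. For the measured compounds named here, only one measured step exists, and it also exchanged one aromatic ring for another on the same aromatic carbon: a number 0.3 percentage points lower from compound 1 to compound 2 (within the scatter). It bears on the present change only loosely, but it gives no sign that a swap of ring at this place moves this assay. No step beyond the scatter is therefore expected for pyridin-2-yl replacing pyridin-4-yl; the expected step is a number 0.1 percentage points lower from compound 2 to compound 3 (within the scatter). Compound 3 is estimated at 32%, with a range from 15% to 50%.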

Compound 3, a percentage reported as inhibition, in the whole organism at one dose (the size of the read-out at that dose, not a potency): 27.5%
Compound 3: the middle estimate sits 4.5 percentage points above what was measured; the measured number falls inside the stated range.
By their numbers in this assay, from the lowest: compounds 3, 2 and 1 (each within the scatter of the next).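

At this position, on the aromatic carbon next to the ring nitrogen of the five-membered ring, exchanging pyridin-4-yl for its isomer pyridin-2-yl gives a number 4.6 percentage points lower from compound 2 to compound 3 (within the scatter) in this assay, so moving the ring nitrogen of the pyridine does not separate the two compounds on this read-out. The change from 3-methyl-1,2-oxazol-5-yl to pyridin-2-yl gives a number 4.9 percentage points lower from compound 1 to compound 3 (within the scatter), so all three aromatic rings shown at this carbon remain unseparated in this assay. No measurement is available that could account for the small differences seen here.

Going by these compounds, whether a group of another kind at this carbon, such as an amine, a carboxylic acid or a longer alkyl chain, would give a step beyond the scatter remains open. The compounds shown also leave open how changes elsewhere on the shared core would affect this read-out.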